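The source may report more compounds than this note shows. Statements on the series, on what has been measured and on what is new or still open speak of the compounds shown alone.

Working notes on the series. Compound 1 `CC1(COc2ccc(-c3ccc(F)nc3F)cn2)CCn2cc([N+](=O)[O-])nc2O1` is examined in an ADME assay on MRC5 cells (Homo sapiens) for cytotoxicity, read by resazurin assay, with a stated time of 72 h; on this read-out higher numbers stand for weaker inhibition and lower numbers for stronger inhibition. In this assay compound 1 gives > 64000 nM, which is a limit of the assay and not a number. Compound 2 `O=[N+]([O-])c1cn2c(n1)OC(COc1ccc(-c3ccc(F)nc3F)cn1)CC2` gives > 64000 nM in this assay, again a limit rather than a number. Compound 3 `CC1(COCc2ccc(OC(F)(F)F)cc2)CCn2cc([N+](=O)[O-])nc2O1` gives > 64000 nM in this assay, also a limit. Within the data shown here, the only single-point step among the measured compounds, a step that the two limits leave unreadable from compound 1 to compound 2, hydrogen in place of methyl on a saturated ring carbon, cannot be sized because of the limit of > 64000 nM in this assay, at which 3 of the 3 values shown sit. Where compound 1 stands is thus known only as that limit, and no measured step gives a scale for any change.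

Compound 4 `CC1(COc2ccc(-c3ccc(F)cn3)cn2)CCn2cc([N+](=O)[O-])nc2O1` differs from compound 1 by 5-fluoropyridin-2-yl in place of 2,6-difluoropyridin-3-yl on an aromatic carbon. Among the measured compounds shown here, no measured step touches this aromatic group, so nothing read so far bears on it. The expected step that the limit leaves unreadable from compound 1 to compound 4 is therefore none beyond the scatter. Compound 4 is expected at 90000 nM in this assay, in the range 40000 nM to 250000 nM, most probably reported again only as a limit.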

Compound 4, half-maximal inhibitory concentration: > 64000 nM
Compound 4: a limit, no number; the forecaster's own chance of this, stated with the estimate: 80%; the middle value does not contradict the limit.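

Among these compounds, compound 4, like compound 1, is reported only as a limit and not as a number, so no step between the two can be read: the limit of > 64000 nM in this assay, at which 4 of the 4 values shown sit. The compounds shown leave open whether any change in this series gives a readable number in this assay.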